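The source may hold more compounds than are shown below. What is called first, only, known or untested is meant among the compounds shown, and "the series" means these compounds.

Measured in an assay on HEK293 cells for displacement of a labelled ligand from Melanocortin receptor 4 (Homo sapiens); on this read-out lower numbers stand for stronger inhibition and higher numbers for weaker inhibition:
compound 1, `CCC(C)[C@H](NCC1CCCO1)c1cc(C(F)(F)F)ccc1N1CCN(C(=O)CCc2ccc(Cl)cc2Cl)CC1`: 780 nM
compound 2, `CCC(C)[C@H](NCc1ccccc1F)c1cc(C(F)(F)F)ccc1N1CCN(C(=O)CCc2ccc(Cl)cc2Cl)CC1`: a limit only, > 10000 nM
compound 3, `CCC(C)[C@H](NC[C@H]1CCCN1)c1cc(C(F)(F)F)ccc1N1CCN(C(=O)CCc2ccc(Cl)cc2Cl)CC1`: 110 nM

Compound 3 gives the lowest of the two numbers in this assay. The step of a 7.1-fold lower number from compound 1 to compound 3 (0.85 log units; beyond the scatter) was modest, and an at least 90-fold lower number from compound 2 to compound 3 (1.95 log units; beyond the scatter) was large. Compound 4, `CC(C)C[C@H](NC(=O)CN)c1cc(C(F)(F)F)ccc1N1CCN(C(=O)CCc2ccc(Cl)cc2Cl)CC1`, differs from compound 3 by 1-(((aminomethyl)carbonyl)amino)-3-methylbutyl in place of 2-methyl-1-(((pyrrolidin-2-yl)methyl)amino)butyl on an aromatic carbon. Going by the values given here, no measured step exchanges the amine linker for an amide, so the earlier steps bear on it only loosely: an at least 12-fold higher number from compound 1 to compound 2 (1.10 log units; beyond the scatter) and a 7.1-fold lower number from compound 1 to compound 3 (0.85 log units; beyond the scatter) show that the group on the saturated chain carbon bound to the amine nitrogen shifts this assay strongly in either direction. Compound 4 is therefore expected to lose ground, a 7.3-fold higher number from compound 3 to compound 4 (0.86 log units; beyond the scatter), with an estimated 800 nM and a range of 150 nM to 5000 nM.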

Compound 4, inhibition constant: 19 nM
Estimate against measurement, compound 4: 42-fold (1.62 log units) above, outside the stated range (below it).
By their numbers in this assay, from the lowest: compound 4; then compound 3; then compound 1. At a limit, above all of these: compound 2.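

In this assay, a 5.8-fold lower number from compound 3 to compound 4 (0.76 log units; beyond the scatter) and a 41-fold lower number from compound 1 to compound 4 (1.61 log units; beyond the scatter) show that this position accepts a carbonyl-bearing amide linker. The ring-free 1-(((aminomethyl)carbonyl)amino)-3-methylbutyl group gives a lower number than either ring-bearing amine, so neither ring is required here. Nothing given here accounts for this gain.

From the compounds shown here alone, the change alters the linker and the branching of the alkyl chain together, so the share of each remains open. Also open, going by these compounds, is how a pyrrolidin-2-yl amide, a longer chain before the terminal amine, or a carboxylic acid in its place would read out.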